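Chain length and terminal amide on the shared core

The source may report more compounds than this note shows. Statements on the series, on what has been measured and on what is new or still open speak of the compounds shown alone.

compound 1 `Nc1ncnc2c1c(-c1cnc3[nH]ccc3c1)nn2CCCC(=O)NO`: > 150000 nM
compound 2 `Nc1ncnc2c1c(-c1cnc3[nH]ccc3c1)nn2CCCCCCCCC(=O)NO`: 11000 nM

In a functional assay on MDA-MB-231 cells (Homo sapiens) for inhibition, read by MTT assay, with a stated time of 72 h (on this read-out higher numbers stand for weaker inhibition and lower numbers for stronger inhibition), compound 1 reaches only a limit, > 150000 nM. Within the data shown here, compound 2 gives 11000 nM, the single number in this assay. The value of compound 1 is a limit (the limit of > 150000 nM in this assay, at which 1 of the 2 values shown sits). Among the measured compounds shown here, the one measured step, an at least 13-fold lower number from compound 1 to compound 2 (1.13 log units; beyond the scatter), lengthens the chain while keeping the hydroxycarbamoyl group. Compound 3 `CNC(=O)CCCCCCCn1nc(-c2cnc3[nH]ccc3c2)c2c(N)ncnc21` differs from compound 2 by methylcarbamoyl in place of (hydroxycarbamoyl)methyl on a saturated chain carbon, seven bonds along the chain from an aromatic nitrogen. For the measured compounds named here, no measured step alters the hydroxycarbamoyl group itself, and the chain grows no longer here. A weaker result is expected for compound 3, a 4.1-fold higher number from compound 2 to compound 3 (0.61 log units; beyond the scatter). Compound 3 is estimated at 45000 nM, within 10000 nM to 150000 nM.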

Compound 3, half-maximal inhibitory concentration: 15800 nM
Estimate against measurement, compound 3: 2.8-fold (0.45 log units) above; the range from low to high includes it.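

In this assay, methylcarbamoyl in place of (hydroxycarbamoyl)methyl on a saturated chain carbon, seven bonds along the chain from an aromatic nitrogen, gives a 1.4-fold higher number from compound 2 to compound 3 (0.16 log units; within the scatter), so the long-chain result does not depend on the hydroxycarbamoyl group here. The long chain ending in methylcarbamoyl still shows an at least 9.4-fold lower number from compound 1 to compound 3 (0.97 log units; beyond the scatter). That step is read against a limit for compound 1: the limit of > 150000 nM in this assay, at which 1 of the 3 values shown sits.

Going by these compounds, whether a carboxylic acid or a primary amide at the chain end would read the same stays open. So does the effect of a longer chain on this number.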